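Bromo in place of (oxiran-2-yl)methoxy on compound 2

The source may report more compounds than this note shows. Statements on the series, on what has been measured and on what is new or still open speak of the compounds shown alone.

Going by the values given here, in a functional assay on M14 cells (Homo sapiens) for cytotoxicity (a higher number here means a weaker inhibitor of growth, a lower number a stronger inhibitor of growth), compound 1 `COc1ccc(C2=C(c3ccc(SC)cc3)CC3CCCN3C2=O)cc1` gives 4000 nM and compound 2 `CSc1ccc(C2=C(c3ccc(OCC4CO4)cc3)C(=O)N3CCCC3C2)cc1` gives 90 nM, the lower of the two numbers measured so far. Compound 3 `CSc1ccc(C2=C(c3ccc(Br)cc3)C(=O)N3CCCC3C2)cc1` has not yet been measured. It carries bromo in place of (oxiran-2-yl)methoxy on an aromatic carbon, para to a large group: bromo in place of (oxiran-2-yl)methoxy on an aromatic carbon.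

Among the compounds with values here, only one measured step bears on this change: a 44-fold lower number from compound 1 to compound 2 (1.65 log units; beyond the scatter), a large step that comes with oxiran-2-yl in place of hydrogen on the saturated chain carbon. Within the data shown here, compound 3 also lacks oxiran-2-yl, so much of that step is expected to be lost, although no measured compound carries bromo and the uncertainty is wide. The expected change in this assay is a move to a higher number, estimated as a 13-fold higher number from compound 2 to compound 3 (1.12 log units; beyond the scatter). For compound 3 the estimated value is 1200 nM, with an expected range of 250 nM to 5000 nM.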

Compound 3, concentration for 50% growth inhibition: 9000 nM
Compound 3: middle estimate off by 7.5-fold (0.88 log units), on the low side; measured number outside the range, above it.
By their numbers in this assay, from the lowest: compound 2; then compound 1; then compound 3.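

In this assay the change to bromo gives a 100-fold higher number from compound 2 to compound 3 (2.00 log units; beyond the scatter), so the low number of compound 2 does not survive on this aromatic carbon once the (oxiran-2-yl)methoxy group leaves. Bromo and methoxy lie much closer together, with a 2.3-fold higher number from compound 1 to compound 3 (0.35 log units; beyond the scatter) as a modest step that is still beyond the scatter, and of the three groups seen at this place only (oxiran-2-yl)methoxy goes with a low number. No measurement here accounts for these steps.

The compounds shown leave open whether the low number needs the three-membered ring itself or would also appear with a 2,3-dihydroxypropoxy chain or a plain propoxy chain. From the compounds shown here alone, how an amine or a carboxylic acid on this carbon would read in the same assay also remains open.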